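This account rests on a few compounds, and the source may have more. Where it says the series, first, only, none or still open, it means among the compounds named here.

Measured in a functional assay on HL-60 cells (Homo sapiens) for antiproliferative activity, with a stated time of 72 h (a higher number here means a weaker inhibitor, a lower number a stronger inhibitor), so far:
compound 1 (`Cc1cccc(CNc2ncnc3c2ncn3[C@@H]2O[C@H](CO)[C@@H](O)[C@H]2O)c1`) gives 6400 nM
compound 2 (`OC[C@H]1O[C@@H](n2cnc3c(NCc4ccc(F)c(F)c4F)ncnc32)[C@H](O)[C@@H]1O`) gives 13000 nM
compound 3 (`Cc1cccc(CNc2ncnc3c2ncn3[C@@H]2O[C@H](CO)[C@@H](O)[C@H]2O)c1O`) gives 15000 nM

Compound 3 sits at the weak end of this short series together with compound 2, the gap being a 1.2-fold higher number from compound 2 to compound 3 (0.06 log units; within the scatter). Compound 1 is the strongest of the three, and the distance to compound 3 is a 2.3-fold higher number from compound 1 to compound 3 (0.37 log units; beyond the scatter).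

Next is compound 4 (`Cc1ccc(O)c(CNc2ncnc3c2ncn3[C@@H]2O[C@H](CO)[C@@H](O)[C@H]2O)c1`), with 2-hydroxy-5-methylphenyl in place of 2-hydroxy-3-methylphenyl on a saturated chain carbon bound to a nitrogen on an aromatic ring. Among the measured compounds shown here, no measured step changes only the place of the methyl. The closest evidence is the hydroxy step, a 2.3-fold higher number from compound 1 to compound 3 (0.37 log units; beyond the scatter), and the change of the whole aryl group, a 2.0-fold higher number from compound 1 to compound 2 (0.31 log units; beyond the scatter), is also modest. On that basis, no large shift is expected in this assay. The expected step is a 1.3-fold lower number from compound 3 to compound 4 (0.10 log units; within the scatter), which would be none beyond the scatter. The estimated value for compound 4 is 12000 nM, with an expected range from 5000 nM to 28000 nM.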

Compound 4, half-maximal inhibitory concentration: 15000 nM
The estimate for compound 4 lay 1.3-fold (0.10 log units) below the measured number; the measured number falls inside the stated range.
By their numbers in this assay, from the lowest: compound 1; then compounds 2, 3 and 4 (each within the scatter of the next).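

In this assay, moving the methyl gives no change at the digits printed from compound 3 to compound 4 (within the scatter), so these two isomers cannot be told apart and the 2-hydroxy-3-methylbenzyl to 2-hydroxy-5-methylbenzyl change has no visible effect on the read-out. The hydroxy step now appears a second time, as a 2.3-fold higher number from compound 1 to compound 4 (0.37 log units; beyond the scatter), and it holds with the methyl in either of these two places. The change of aryl group gives a 1.2-fold higher number from compound 2 to compound 4 (0.06 log units; within the scatter), so 2-hydroxy-5-methylphenyl and 2,3,4-trifluorophenyl also cannot be separated here.

No data on hand explain why the place of the methyl leaves the number unmoved. Still open, as far as these compounds go, is whether an amine or a carboxylic acid in place of the hydroxy, or a longer chain in place of the benzyl link, would shift the number from that of compound 1, at 6400 nM.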